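Swapping the aryl group on the sulfonyl sulfur

The source may hold more compounds than are shown below. What is called first, only, known or untested is meant among the compounds shown, and "the series" means these compounds.

Three compounds share one core. Compound 1 `COc1cc2nc(N3CCN(S(=O)(=O)c4ccc(Br)cc4)CC3)nc(N)c2cc1OC` gives 20000 nM in a functional assay on PC-3 cells (Homo sapiens) for inhibition; on this read-out higher numbers stand for weaker inhibition and lower numbers for stronger inhibition. Compound 2 `COc1cc2nc(N3CCN(S(=O)(=O)c4ccccc4[N+](=O)[O-])CC3)nc(N)c2cc1OC` gives 35000 nM, the highest of the three numbers, although a 1.8-fold higher number from compound 1 to compound 2 (0.24 log units; within the scatter). Compound 3 `COc1cc2nc(N3CCN(S(=O)(=O)c4ccc(S(C)(=O)=O)cc4)CC3)nc(N)c2cc1OC` gives 17000 nM, and a 2.1-fold lower number from compound 2 to compound 3 (0.31 log units; beyond the scatter).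

Compound 4 `COc1cc2nc(N3CCN(S(=O)(=O)c4cc(C(=O)O)c(Cl)cc4Cl)CC3)nc(N)c2cc1OC` is not yet measured. It differs from compound 2 in one place: 5-carboxy-2,4-dichlorophenyl in place of 2-nitrophenyl on a sulfonyl sulfur.

Both measured steps that change the aryl group on the sulfonyl sulfur stayed close to the scatter, so such swaps have moved the numbers little so far. A similarly small step is therefore expected here, likely a modest lowering, and compound 4 is estimated at 25000 nM, within 10000 nM to 60000 nM, which would mean a 1.4-fold lower number from compound 2 to compound 4 (0.15 log units; within the scatter).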

Compound 4, half-maximal inhibitory concentration: 52000 nM
The estimate for compound 4 lay 2.1-fold (0.32 log units) below the measured number; low and high end bracket the measured number.
By their numbers in this assay, from the lowest: compounds 3, 1, 2 and 4 (each within the scatter of the next, the first and the last beyond it).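

The 5-carboxy-2,4-dichlorophenyl group gives the widest step yet seen on the sulfonyl sulfur, with a 3.1-fold higher number from compound 3 to compound 4 (0.49 log units; beyond the scatter) and a 2.6-fold higher number from compound 1 to compound 4 (0.41 log units; beyond the scatter) in this assay. Against the 2-nitrophenyl group, however, there is a 1.5-fold higher number from compound 2 to compound 4 (0.17 log units; within the scatter) and so no clear separation, which means that adding a carboxy group and two chlorines to the ring did not clearly set compound 4 apart from every other aryl choice.

As far as these compounds go, whether the sulfonyl sulfur needs an aryl group at all stays open, as does what an amine or a longer chain would do there. No measurement shown explains these steps.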